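A few compounds are considered here, and "the series" means these few. Any claim that something is new, unique, unknown or untested is made for them only; others in the source may bear on it.

Measured so far in a functional assay on MDA-MB-468 cells (Homo sapiens) for inhibition, read by sulforhodamine B assay, with a stated time of 48 h; on this read-out higher numbers stand for weaker inhibition and lower numbers for stronger inhibition:
compound 1 `O=C(Nc1cccc(-n2cc(-c3ccncc3)c(-c3ccc(Cl)c(O)c3)n2)c1)Nc1cccc(C(F)(F)F)c1` gives 980 nM
compound 2 `COc1cc(-c2nn(-c3cccc(NC(=O)Nc4cc(C(F)(F)F)cc(C(F)(F)F)c4)c3)cc2-c2ccncc2)ccc1Cl` gives 310 nM

Compound 1 stands at the highest of the two numbers in this assay; the number for compound 2 is lower, beyond the scatter. Compound 1 and compound 2 differ in more than one place, so the pair cannot be read as a single change.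

Compound 3 `O=C(Nc1cccc(-n2cc(-c3ccncc3)c(-c3ccc(Cl)c(O)c3)n2)c1)Nc1ccc(Cl)c(Cl)c1` has not yet been measured in this assay. It differs from compound 1 in one place: 3,4-dichlorophenyl in place of 3-(trifluoromethyl)phenyl on an amide-type nitrogen. Within the data shown here, no measured pair isolates this change, so the expectation rests on the two numbers alone. The step from compound 1 to compound 3 is expected to be small, at most toward a lower number, and may not pass beyond the scatter: a 1.4-fold lower number from compound 1 to compound 3 (0.15 log units; within the scatter). For compound 3 the expected value in this assay is 700 nM, with a range from 250 nM to 2000 nM.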

Compound 3, half-maximal inhibitory concentration: 730 nM
For compound 3 the middle estimate is 1.0-fold (0.02 log units) below the measured one; measured number inside the range.
By their numbers in this assay, from the lowest: compound 2; then compounds 3 and 1 (each within the scatter of the next).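

In this assay, 3,4-dichlorophenyl in place of 3-(trifluoromethyl)phenyl on an amide-type nitrogen gives a 1.3-fold lower number from compound 1 to compound 3 (0.13 log units; within the scatter). Among these compounds, this is the first pair that isolates a change at this position, and with the rest of compound 1 held fixed, this read-out does not separate the two substituted phenyl groups. No measurement at hand bears on why the two groups read alike.

From the compounds shown here alone, whether this holds beyond these two groups stays open, for example with a cyclohexyl or a pyridyl group on the amide-type nitrogen. Compound 1 and compound 3 each differ from compound 2 in more than one place, so for compound 2 the value of 310 nM cannot be assigned to any one of its groups.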